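Fluoro for nitro on a quinolone amide series

The source may report more compounds than this note shows. Statements on the series, on what has been measured and on what is new or still open speak of the compounds shown alone.

Compound 1 `COc1cc(OC)c2c(=O)cc(C(=O)Nc3ccc(C4CCCCC4)cc3)[nH]c2c1`: "not determined" (no result reported)
Compound 2 `COc1cc(OC)c2c(=O)cc(C(=O)Nc3ccc(N4CCN(C)CC4)cc3)[nH]c2c1`: > 19800 nM
Compound 3 `COc1cc(OC)c2c(=O)cc(C(=O)Nc3ccc(Oc4ccc([N+](=O)[O-])cc4)cc3)[nH]c2c1`: "not determined" (no result reported)

In a functional assay on UoC-B1 cells (Homo sapiens) for antiproliferative activity, with a stated time of 72 h (on this read-out lower numbers stand for an effect already at smaller amounts and higher numbers for an effect only at larger amounts of compound), compound 3 has no number of its own. Compound 2 reached only a limit of the assay, > 19800 nM, so it gives no number either. Compound 1 likewise has no result. Among the compounds with values here, nothing measured here sets a scale for compound 3, and no step between measured compounds is available. Compound 4 `COc1cc(OC)c2c(=O)cc(C(=O)Nc3ccc(Oc4ccc(F)cc4)cc3)[nH]c2c1` differs from compound 3 in one place: fluoro in place of nitro on an aromatic carbon. Within the data shown here, with no measured step to lean on, the size and direction of the change in this assay cannot be expected with confidence; the one result that exists, for compound 2, is a limit. Compound 4 is estimated at 12000 nM, within 2000 nM to 30000 nM.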

Compound 4, half-maximal effective concentration: > 50000 nM
Compound 4: only a limit was reported; the forecaster's own chance of this, stated with the estimate: 50%; middle value at least 4.1-fold (0.61 log units) from the limit.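

In this assay, within the data shown here, compound 2 and compound 4 each gave only a limit, not a number, and no step between them can be read. On these data alone, what swapping nitro for fluoro changes, from compound 3 to compound 4, stays open.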